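The source may report more compounds than this note shows. Statements on the series, on what has been measured and on what is new or still open speak of the compounds shown alone.

Of the compounds shown here, two built on the same core have been measured so far. Compound 1 `COc1cc2oc(-c3ccccc3)cc(=O)c2c(O)c1OCCCN1CCN(C)CC1` gives 31300 nM in a functional assay on BCG823 cells (Homo sapiens) for antiproliferative activity, read by MTT assay, with a stated time of 48 h; on this read-out lower numbers stand for stronger inhibition and higher numbers for weaker inhibition. Compound 2 `COc1cc2oc(-c3ccccc3)cc(=O)c2c(O)c1OCCCN1CCCC1` gives 6500 nM in this assay, the lowest of the two numbers and therefore the stronger inhibitor of the pair, with compound 1 as its nearest neighbour. Among the measured compounds shown here, the only measured step is a 4.8-fold lower number from compound 1 to compound 2 (0.68 log units; beyond the scatter).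

Compound 3 `COc1cc2oc(-c3ccccc3)cc(=O)c2c(O)c1OCCCCN1CCN(C)CC1` has not yet been measured. It differs from compound 2 in one place: (4-methylpiperazin-1-yl)methyl in place of pyrrolidin-1-yl on a saturated chain carbon, three bonds along the chain from an oxygen on an aromatic ring. The change thus brings back the 4-methylpiperazin-1-yl group that compound 1 carries, but on a chain one carbon longer. For the measured compounds named here, only the step from compound 1 to compound 2 bears on this, and it ran the other way, so the number is expected to move back up, although the longer chain is untested and keeps the expectation loose. The expected step is a 3.1-fold higher number from compound 2 to compound 3 (0.49 log units; beyond the scatter). Compound 3 is therefore estimated at 20000 nM in this assay, within a range from 7000 nM to 55000 nM.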

Compound 3, half-maximal inhibitory concentration: 53500 nM
Beside the measured number, compound 3's estimate is 2.7-fold (0.43 log units) below it; low and high end bracket the measured number.
By their numbers in this assay, from the lowest: compound 2; then compounds 1 and 3 (each within the scatter of the next).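

In this assay, lengthening the chain that carries the 4-methylpiperazin-1-yl ring gives a 1.7-fold higher number from compound 1 to compound 3 (0.23 log units; within the scatter) and so no readable change: at this position, the longer chain alone does not separate compound 1 from compound 3. The other new comparison shows an 8.2-fold higher number from compound 2 to compound 3 (0.92 log units; beyond the scatter) on replacing pyrrolidin-1-yl with (4-methylpiperazin-1-yl)methyl, so across these three compounds the clear differences follow the ring at the chain end rather than the chain length, and compound 2 remains the strongest inhibitor, with its steps to both others beyond the scatter. No supporting measurement is available to explain this difference between the two rings.

On these data alone, what remains open is whether pyrrolidin-1-yl would hold its advantage on the longer chain of compound 3, since the shorter chain is the only one on which it appears here. It is also unknown how other cyclic amines, such as piperidin-1-yl or morpholin-4-yl, or a still longer chain would compare at this position.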